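The source may report more compounds than this note shows. Statements on the series, on what has been measured and on what is new or still open speak of the compounds shown alone.

Measured compounds:
compound 1 `N#Cc1cnc(NCc2cnccc2C(F)(F)F)cc1NC[C@H]1C[C@@H](O)C1` — 4200 nM
compound 2 `N#Cc1cnc(NCc2cnccc2C(F)(F)F)cc1NC[C@H]1CC[C@@H](O)CC1` — 500 nM
compound 3 `N#Cc1cnc(NCc2cnccc2C(F)(F)F)cc1NC[C@H]1CC[C@H](O)CC1` — 2000 nM

In an assay on isolated protein for inhibition of protein kinase C delta type (Homo sapiens), read by TR-FRET, with a stated time of 2 h (on this read-out higher numbers stand for weaker inhibition and lower numbers for stronger inhibition), compound 3 stands second highest of the three numbers. Compound 1 sits above it, with a 2.1-fold lower number from compound 1 to compound 3 (0.32 log units; beyond the scatter). Compound 2 sits below it, with a 4.0-fold higher number from compound 2 to compound 3 (0.60 log units; beyond the scatter), a step that rests only on (the fact that compounds 2 and 3 differ only in the configuration as drawn).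

Compound 4 `CNC(=O)[C@H]1CC[C@@H](Nc2cc(NCc3cnccc3C(F)(F)F)ncc2C#N)CC1` is the next candidate. It differs from compound 3 by 4-(methylcarbamoyl)cyclohexyl in place of (4-hydroxycyclohexyl)methyl on a nitrogen on an aromatic ring. Going by the values given here, no measured step covers this change: the three measured steps only swap the hydroxylated ring or invert its stereocentres, and together they span an 8.4-fold lower number from compound 1 to compound 2 (0.92 log units; beyond the scatter) at the widest, so this region of the molecule clearly moves the read-out. The change to compound 4 is larger in kind than any measured step, removing the chain carbon and replacing the hydroxyl with a methylcarbamoyl group, so the direction cannot be read from the data. The expectation for compound 4 is therefore a number near that of compound 3, with a wide range in both directions; the expected step is a 1.3-fold lower number from compound 3 to compound 4 (0.12 log units; within the scatter), within the scatter. Compound 4 is estimated at 1500 nM in this assay, with a range from 300 nM to 8000 nM.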

Compound 4, half-maximal inhibitory concentration: 1600 nM
Compound 4: the middle estimate sits 1.1-fold (0.03 log units) below what was measured; the range from low to high includes it.
By their numbers in this assay, from the lowest: compound 2; then compounds 4 and 3 (each within the scatter of the next); then compound 1.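

In this assay, the place on a nitrogen on an aromatic ring takes 4-(methylcarbamoyl)cyclohexyl in place of (4-hydroxycyclohexyl)methyl with no readable shift (a 1.3-fold lower number from compound 3 to compound 4 (0.10 log units; within the scatter)), so neither the hydroxyl nor the chain carbon is required to hold a number at the level of compound 3. The same group does not match the hydroxylated ring of compound 2 (a 3.2-fold higher number from compound 2 to compound 4 (0.51 log units; beyond the scatter)), yet it stays clear of the (3-hydroxycyclobutyl)methyl group of compound 1 (a 2.6-fold lower number from compound 1 to compound 4 (0.42 log units; beyond the scatter)). The chain carbon and the ring substituent change together in this swap, so the flat step cannot be divided between them.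

Still open, on these data alone, is how much the drawn configuration of 4-(methylcarbamoyl)cyclohexyl matters, given that the hydroxylated pair moves on configuration alone (a 4.0-fold higher number from compound 2 to compound 3 (0.60 log units; beyond the scatter)): (the fact that compounds 2 and 3 differ only in the configuration as drawn). Also open, as far as these compounds go, is whether a carboxylic acid or a primary amine on the same cyclohexyl ring, or the methylcarbamoyl group with the chain carbon restored, would bring the number to that of compound 2 or lower.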